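From an ester to a butyl amide: an expected step

A few compounds are considered here, and "the series" means these few. Any claim that something is new, unique, unknown or untested is made for them only; others in the source may bear on it.

Compound 1 `COc1ccc2c(c1)OC(c1cc(OC)c(OC)c(OC)c1)C(CO)=C2` gives > 50000 nM in a functional assay for inhibition of nuclear factor NF-kappa-B complex (Homo sapiens); on this read-out higher numbers stand for weaker inhibition and lower numbers for stronger inhibition; compound 2 `COc1ccc2c(c1)OC(c1cc(OC)c(OC)c(OC)c1)C(C(=O)OCCc1ccccc1)=C2` gives 16200 nM.

For compound 1 the value > 50000 nM is a limit of this assay and not a number. Compound 2 therefore holds the only number shown, which is also the reason the step of an at least 3.0-fold lower number from compound 1 to compound 2 (0.48 log units; beyond the scatter) is given as a lower bound (the limit of > 50000 nM in this assay, at which 1 of the 2 values shown sits).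

Compound 3 `CCCCNC(=O)C1=Cc2ccc(OC)cc2OC1c1cc(OC)c(OC)c(OC)c1` keeps the carbonyl of compound 2 but changes what hangs on it: butylamino in place of phenethyloxy on a carbonyl carbon. Within the data shown here, the one measured step bears on this position, since it concerns the same carbon bearing the hydroxymethyl or the phenethyloxycarbonyl, yet it does not separate the carbonyl from the phenethyloxy part. Because that step is an at least 3.0-fold lower number from compound 1 to compound 2 (0.48 log units; beyond the scatter) and nothing shows what the butylamino adds, compound 3 is expected to move little, with the step of a 1.2-fold higher number from compound 2 to compound 3 (0.09 log units; within the scatter) estimated to stay within the scatter. The value for compound 3 is thus estimated at 20000 nM, between 7000 nM and 55000 nM.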

Compound 3, half-maximal inhibitory concentration: 25500 nM
For compound 3 the middle estimate is 1.3-fold (0.11 log units) below the measured one, within the range that was stated.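

In this assay, butylamino in place of phenethyloxy on a carbonyl carbon is the step of a 1.6-fold higher number from compound 2 to compound 3 (0.20 log units; within the scatter), so at this position, for these two compounds, an ester with an aromatic ring and an amide with a plain chain cannot be told apart. Compound 1 carries a limit and not a number: the limit of > 50000 nM in this assay, at which 1 of the 3 values shown sits. Set against it, the butylcarbamoyl group gives the step of an at least 1.9-fold lower number from compound 1 to compound 3 (0.29 log units; that floor lies within the scatter), and with that floor inside the scatter, this pair alone does not show that the amide does better than hydroxymethyl.

Going by these compounds, it remains open whether the carbonyl itself or the chain attached to it matters more. A carboxylic acid, or a methylamino or longer alkylamino group on the same carbonyl carbon, would help to separate the two.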